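Methyl for isopropyl on the ring amine nitrogen

The source may hold more compounds than are shown below. What is called first, only, known or untested is meant among the compounds shown, and "the series" means these compounds.

Values in an in vivo ADME assay on the whole organism for metabolic stability, with Homo sapiens as the target, read by LC-MS, at a dose of 160 mg/kg by the oral route (a higher number here means that the compound lasts longer, a lower number that the compound disappears faster), so far:
compound 1 `CC(C)N1CC(=O)N=C1NC(=N)Nc1ccc(Cl)c(Cl)c1`: > 1 h
compound 2 `CN1CC(=O)N=C1NC(=N)Nc1ccc(Cl)c(Cl)c1`: > 1 h
compound 3 `CC(C)N1CC(=O)N=C1N/C(=N\C(=O)OC(C)(C)C)Nc1ccc(Cl)c(Cl)c1`: 0.213 h

Compound 1 and compound 2 share one core and differ only in methyl in place of isopropyl on an amine nitrogen in a ring. In this assay compound 1 gives > 1 h, a limit of the assay and not a number. Compound 2 gives > 1 h, likewise a limit. The measured instance of the change is thus a step that the two limits leave unreadable from compound 1 to compound 2. What the pair does show is the limit of > 1 h in this assay, at which 2 of the 3 values shown sit.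

Compound 3 differs from compound 1 in more than one place; the difference between the two cores is not broken down here. In this assay, going by the values given here, compound 3 gives 0.213 h, the only number in the set.

Compound 4 `CN1CC(=O)N=C1N/C(=N\C(=O)OC(C)(C)C)Nc1ccc(Cl)c(Cl)c1` is not yet measured. It stands to compound 3 as compound 2 stands to compound 1: methyl in place of isopropyl on an amine nitrogen in a ring, the same change at the same place. The step expected here is a 1.2-fold higher number from compound 3 to compound 4 (0.07 log units; within the scatter). No readable precedent exists for it, the earlier instance being unreadable. Compound 4 is therefore expected to land near 0.25 h, between 0.1 h and 0.7 h.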

Compound 4, half-life: < 0.167 h
Compound 4: only a limit was reported (the forecaster's own chance of this, stated with the estimate: 15%); middle value at least 1.4-fold (0.17 log units) from the limit.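

In this assay, going by these compounds alone, the one readable instance of methyl in place of isopropyl on an amine nitrogen in a ring gives a floor and no more, because compound 4 carries a limit and not a number: an at least 1.2-fold lower number from compound 3 to compound 4 (0.10 log units; that floor lies within the scatter). The same change on the core of compound 1 cannot be read, since both ends of that pair are limits: the limit of > 1 h in this assay, at which 2 of the 4 values shown sit. The series therefore shows no measured transfer of this change from one core to the other: it neither supports nor excludes a shared direction, and the one floor does not settle a change beyond the scatter on either core.

Open, as far as these compounds go, is how the half-life on each core would respond to other groups on the same ring nitrogen, such as ethyl, cyclopropyl or a longer chain ending in an amine. Also open, from the compounds shown here alone, is the true size of the step on each core, which needs numbers in place of the limits at compound 1, compound 2 and compound 4.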